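From Octyl to Isopropyl on a Sulfur

The source may report more compounds than this note shows. Statements on the series, on what has been measured and on what is new or still open speak of the compounds shown alone.

Four compounds sharing one core are considered here: compound 1 `CC(C)CSc1nc(N)nc2c1ncn2/C=C1/CC1(CO)CO`, compound 2 `CC(C)Nc1nc(N)nc2c1ncn2/C=C1/CC1(CO)CO`, compound 3 `CCCCCCCCSc1nc(N)nc2c1ncn2/C=C1/CC1(CO)CO` and compound 4 `CC(C)Sc1nc(N)nc2c1ncn2/C=C1/CC1(CO)CO`. In an ADME assay on MOLT-3 cells (Homo sapiens) for cytotoxicity, with a stated time of 7 days (on this read-out higher numbers stand for lower toxicity in this test and lower numbers for higher toxicity in this test), the entry for compound 1 reads "not determined" (no result reported). The entry for compound 2 reads "not determined" (no result reported).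

Compound 3 gives > 20000 nM, which is a limit of the assay and not a number. Among the measured compounds shown here, the evidence so far therefore comes down to the limit of > 20000 nM in this assay, at which 1 of the 3 values shown sits, and no step between two measured compounds is available as a guide.

Compound 4 remains to be measured in this assay. It carries isopropyl in place of octyl on a sulfur, while the rest of the structure matches compound 3.

The expected change is small: either a modest shift towards higher numbers or nothing beyond the scatter. The expectation rests on compound 3 alone, whose limit is > 20000 nM. The expected move is a step that the limit leaves unreadable from compound 3 to compound 4. It would not be surprising if the assay again reported only a limit. For compound 4 the estimated half-maximal cytotoxic concentration is 40000 nM, with an expected range from 15000 nM to 100000 nM.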

Compound 4, half-maximal cytotoxic concentration: > 20000 nM
Compound 4: a limit, no number; the forecaster's own chance of this, stated with the estimate: 75%; the middle value is on the limit's open side.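

In this assay, among the compounds shown here, compound 3 and compound 4 both end at a limit and not at a number, so no step between them can be read. The compounds shown leave open whether isopropyl in place of octyl on a sulfur changes the half-maximal cytotoxic concentration at all, because the evidence stops at: the limit of > 20000 nM in this assay, at which 2 of the 4 values shown sit.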